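A few compounds are considered here, and "the series" means these few. Any claim that something is new, unique, unknown or untested is made for them only; others in the source may bear on it.

In a physicochemical assay for solubility, in phosphate buffer, at pH 7.4 (on this read-out higher numbers stand for higher solubility and lower numbers for lower solubility), compound 2 `O=C(O)CCC(=O)OCn1ncc2cc(Nc3ncc(-c4ccc(Cl)cc4)o3)ccc21` gives 60000 nM, the highest of the two numbers available. Compound 1 `Clc1ccc(-c2cnc(Nc3ccc4[nH]ncc4c3)o2)cc1` gives 200 nM, and the step of a 300-fold higher number from compound 1 to compound 2 (2.48 log units; beyond the scatter) came with (((2-carboxyethyl)carbonyl)oxy)methyl in place of hydrogen on an aromatic nitrogen. Compound 3 `O=C(O)c1ccccc1C(=O)OCn1ncc2cc(Nc3ncc(-c4ccc(Cl)cc4)o3)ccc21` alters that added group: 2-carboxyphenyl in place of 2-carboxyethyl on a carbonyl carbon. Among the measured compounds shown here, no measured step covers this swap; the single step of a 300-fold higher number from compound 1 to compound 2 (2.48 log units; beyond the scatter) is the only comparison, and it concerns a different change. Compound 3 is therefore expected to stay high but somewhat lower, a 2.4-fold lower number from compound 2 to compound 3 (0.38 log units; beyond the scatter), at an estimated 25000 nM with a range from 6000 nM to 80000 nM.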

Compound 3, solubility: 66000 nM
Compound 3: the middle estimate sits 2.6-fold (0.42 log units) below what was measured; measured number inside the range.
By their numbers in this assay, from the lowest: compound 1; then compounds 2 and 3 (each within the scatter of the next).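

The swap to 2-carboxyphenyl gives a 1.1-fold higher number from compound 2 to compound 3 (0.04 log units; within the scatter) in this assay, so the two numbers cannot be told apart. At this place on the carbonyl carbon, a six-membered aromatic ring of carbon only can therefore stand in for the open 2-carboxyethyl chain without a measurable shift in the read-out. No measurement here explains why the number holds.

The compounds shown leave open whether a longer chain ending in a carboxylic acid would give a similar number. They also leave open how a chain ending in an amine would read.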